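The compounds below may be only part of what the source reports. "The series", "measured", "known", "first", "only" and "open" are said of these compounds alone.

Measured so far in an ADME assay on a cell-free system (plasma, Homo sapiens) for metabolic stability, read by LC-MS; on this read-out lower numbers stand for a shorter-lived compound and higher numbers for a longer-lived compound:

Compound 1 `COC(=O)c1cccc(-c2cc(C(=O)Nc3ccncc3)ccc2CN)c1` gives 1.52 h.
Compound 2 `NCc1ccc(C(=O)Nc2ccncc2F)cc1-c1cccc(C(=O)OC2CCCOC2)c1` gives 0.3 h.

Compound 1 stands highest of the two numbers in this assay; compound 2 is the nearest, with a lower number, and that gap lies beyond the usual scatter. The two compounds differ from one another in more than one place, so nothing beyond what their two values show can be said about any single change between them.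

Compound 3 `NCc1ccc(C(=O)Nc2ccncc2)cc1-c1cccc(C(=O)OCC2CCCC2)c1` has not yet been measured. It differs from compound 1 in one place: cyclopentyl in place of hydrogen on a saturated chain carbon bound to an oxygen next to a carbonyl group. The methyl ester of compound 1 thus becomes a cyclopentylmethyl ester. Within the data shown here, with no step between measured compounds to lean on, the step from compound 1 to compound 3 in this assay is expected to be small, a 1.5-fold lower number from compound 1 to compound 3 (0.18 log units; within the scatter), and not clearly beyond the scatter. Compound 3 is estimated at 1 h, with a range from 0.35 h to 3 h.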

Compound 3, half-life: 0.517 h
Beside the measured number, compound 3's estimate is 1.9-fold (0.29 log units) above it, and the stated range covers the measured number.
By their numbers in this assay, from the lowest: compounds 2 and 3 (each within the scatter of the next); then compound 1.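

Turning the methyl ester into a cyclopentylmethyl ester, with cyclopentyl in place of hydrogen on a saturated chain carbon bound to an oxygen next to a carbonyl group, gives a 2.9-fold lower number from compound 1 to compound 3 (0.47 log units; beyond the scatter) in this assay and so provides the first reading of a single change. The earlier pair differed in more than one place, whereas this step shows that a change at this position alone can move the half-life in this assay beyond the scatter, though only modestly. The information at hand offers no explanation for the direction or size of this step.

On these data alone, one step sets no trend, so it remains open where an ethyl ester, a longer straight chain or a tert-butyl ester would stand on this read-out. As far as these compounds go, it also remains open how an amide or a carboxylic acid in place of the ester would behave in this assay at this position.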